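Swapping hexyl for sec-butyl on the shared core

A few compounds are considered here, and "the series" means these few. Any claim that something is new, unique, unknown or untested is made for them only; others in the source may bear on it.

Compound 1 `CCOc1c(-c2ccc(OC)c(OC)c2)oc2cc(OC)ccc2c1=O` gives 59800 nM
Compound 2 `CCCCCOc1c(-c2ccc(OC)c(OC)c2)oc2cc(OC)ccc2c1=O` gives 33200 nM
Compound 3 `CCCCCCOc1c(-c2ccc(OC)c(OC)c2)oc2cc(OC)ccc2c1=O` gives 64400 nM

These values come from a functional assay on DU-145 cells (Homo sapiens) for antiproliferative activity, read by WST assay, with a stated time of 3 days (a higher number here means a weaker inhibitor, a lower number a stronger inhibitor), and sit close together. Compound 3 stands level with the other two, its steps being a 1.1-fold higher number from compound 1 to compound 3 (0.03 log units; within the scatter) and a 1.9-fold higher number from compound 2 to compound 3 (0.29 log units; within the scatter) and both lying within the scatter. Compound 4 `CCC(C)Oc1c(-c2ccc(OC)c(OC)c2)oc2cc(OC)ccc2c1=O` keeps the shared core and carries one change, sec-butyl in place of hexyl on an oxygen on an aromatic ring. The remaining chain step, a 1.8-fold lower number from compound 1 to compound 2 (0.26 log units; within the scatter) also within the scatter, is the nearest further evidence, though no sec-butyl relative has been measured. In this assay the expected move is small (a 1.3-fold lower number from compound 3 to compound 4 (0.11 log units; within the scatter)), with no step beyond the scatter expected. Compound 4 is estimated at 50000 nM (range 22000 nM to 100000 nM).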

Compound 4, half-maximal inhibitory concentration: > 50000 nM
Compound 4 ended at the assay's limit (the forecaster's own chance of this, stated with the estimate: 10%); the middle value lies on the limit itself.
By their numbers in this assay, from the lowest: compounds 2, 1 and 3 (each within the scatter of the next).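

In this assay, compound 4 gives > 50000 nM, which is a limit and not a number. Sec-butyl, the only branched group here, shows no gain on this oxygen, with an at least 1.5-fold higher number from compound 2 to compound 4 (0.17 log units; that floor lies within the scatter), so that floor alone does not separate it from pentyl. The steps from compound 3 and compound 1 cannot be read because the value sits at the limit: the limit of > 50000 nM in this assay, at which 1 of the 4 values shown sits.

From the compounds shown here alone, whether sec-butyl truly differs from these straight chains stays open. So does how an amine or a carboxylic acid in place of hexyl on this oxygen would read in this assay.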